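The source may report more compounds than this note shows. Statements on the series, on what has been measured and on what is new or still open speak of the compounds shown alone.

Compound 1 `O=C(Nc1cccc(-n2cc(-c3ccncc3)c(-c3ccc(Cl)c(O)c3)n2)c1)Nc1cccc(C(F)(F)F)c1`: in a functional assay on A549 cells (Homo sapiens) for inhibition, read by sulforhodamine B assay, with a stated time of 48 h (a lower number here means that less compound is tolerated, a higher number that more compound is tolerated), compound 1 gives > 32500 nM, which is a limit of the assay and not a number.
Compound 2 `COc1cc(-c2nn(-c3cccc(NC(=O)c4cccc(C(F)(F)F)c4)c3)cc2-c2ccncc2)ccc1Cl`: in this assay compound 2 gives > 50000 nM, again a limit and not a number.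
Compound 3 `O=C(Nc1cccc(-n2cc(-c3ccncc3)c(-c3ccc(Cl)c(O)c3)n2)c1)Nc1cc(C(F)(F)F)cc(C(F)(F)F)c1`: in this assay compound 3 gives 11400 nM.

Compound 2 therefore stands at the limit of > 50000 nM in this assay, at which 1 of the 3 values shown sits, the weaker of the two limits shown, and nothing more than that limit is known of it. Compound 1 sits at the limit of > 32500 nM in this assay, at which 1 of the 3 values shown sits.

Compound 4 `COc1cc(-c2nn(-c3cccc(NC(=O)Nc4ccc(Cl)c(C(F)(F)F)c4)c3)cc2-c2ccncc2)ccc1Cl` differs from compound 2 in one place: (4-chloro-3-(trifluoromethyl)phenyl)amino in place of 3-(trifluoromethyl)phenyl on a carbonyl carbon. The amide of compound 2 becomes a urea whose aryl carries both a chlorine and a trifluoromethyl group. Going by the values given here, the one measured step that bears on this is an at least 2.8-fold lower number from compound 1 to compound 3 (0.45 log units; beyond the scatter), where a second trifluoromethyl group on the urea aryl carried compound 1 from its limit to a measured number. Compound 4 likewise gains a second substituent on the urea aryl, though it starts from an amide and keeps the methoxy of compound 2, for which no step is shown. Compound 4 is thus expected to move in the same direction, at least modestly, with a fair chance of remaining at a limit.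

Compound 4 is estimated at 20000 nM, between 8000 nM and 60000 nM. The expected step is an at least 2.5-fold lower number from compound 2 to compound 4 (0.39 log units; beyond the scatter).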

Compound 4, concentration lethal to 50% of the cells: > 32500 nM
Compound 4 was reported as a limit; the forecaster's own chance of this, stated with the estimate: 35%; at least 1.6-fold (0.21 log units) between middle value and limit.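

Compound 2 and compound 4 are both reported in this assay only as limits, so the step between them cannot be read. The compounds shown leave open whether (4-chloro-3-(trifluoromethyl)phenyl)amino in place of 3-(trifluoromethyl)phenyl on that carbonyl carbon changes the number at all.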